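The compounds below may be only part of what the source reports. "The series", "measured", "known", "first", "only" and "open" are said of these compounds alone.

Values in a functional assay on HCT-116 cells (Homo sapiens) for antiproliferative activity, read by MTT assay, with a stated time of 72 h (on this read-out lower numbers stand for stronger inhibition and higher numbers for weaker inhibition), for the measured compounds:

compound 1 `CCOC(=O)c1csc2nc(CN3CCN(C)CC3)c(-c3ccc(C)cc3)n12`: 61000 nM
compound 2 `CCOC(=O)c1csc2nc(CN3CCN(C)CC3)c(-c3ccc(OC)cc3)n12`: 44600 nM
compound 3 `Cc1ccc(-c2c(CN3CCCCC3)nc3scc(C(=O)O)n23)cc1`: 13800 nM

Compound 1 and compound 2 share one core and differ in a single place: methoxy in place of methyl on an aromatic carbon. That change brings a 1.4-fold lower number from compound 1 to compound 2 (0.14 log units; within the scatter). Compound 3 stands on a different core; how that core differs from the core of compound 1 is not broken down here. Among the three measured compounds, compound 3 gives the lowest number, beyond the scatter from compound 2 and from compound 1.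

Compound 4 `COc1ccc(-c2c(CN3CCCCC3)nc3scc(C(=O)O)n23)cc1` has not yet been measured. It stands to compound 3 as compound 2 stands to compound 1: methoxy in place of methyl on an aromatic carbon, the same change, made at a place described in the same words. Because the step of a 1.4-fold lower number from compound 1 to compound 2 (0.14 log units; within the scatter) lies within the scatter, the step in this assay is expected to be small as well, a 1.4-fold lower number from compound 3 to compound 4 (0.14 log units; within the scatter). This expectation rests on one measured pair only, on another core. Compound 4 is therefore estimated at 10000 nM, with a range from 4000 nM to 25000 nM.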

Compound 4, half-maximal inhibitory concentration: 84600 nM
Beside the measured number, compound 4's estimate is 8.5-fold (0.93 log units) below it; measured number above the stated range.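

In this assay, methoxy in place of methyl on an aromatic carbon, read as 4-methylphenyl to 4-methoxyphenyl, gives a 6.1-fold higher number from compound 3 to compound 4 (0.79 log units; beyond the scatter). The step therefore does not carry over unchanged between these two cores, and its size depends on the core it is made on: the same change on two cores in this assay, a 1.4-fold lower number (0.14 log units; within the scatter) from compound 1 to compound 2 and a 6.1-fold higher number (0.79 log units; beyond the scatter) from compound 3 to compound 4, 8.4-fold (0.92 log units) apart, beyond the scatter of two such steps

Among these compounds, with only one pair on each core, this does not show which of the structural differences between the core of compound 1 and the core of compound 3 sets the two steps apart, why they differ, or what the same change would do on any further core.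

Still open, from the compounds shown here alone, is how a chlorine atom or a hydroxy group would read in place of the methyl of compound 3, which would show whether the higher number is peculiar to methoxy on this core. Also open, going by these compounds, is whether a primary amide in place of the carboxylic acid of compound 3 would keep the same step for this change.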